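Cyclobutyl amide in the hexyl-linked iminosugar series

The compounds below may be only part of what the source reports. "The series", "measured", "known", "first", "only" and "open" are said of these compounds alone.

Measured so far:
compound 1 `CC(C)(C)C(=O)N(CCCCCCN1C[C@H](O)[C@@H](O)[C@H](O)[C@H]1CO)C1CCCCC1`: in an ADME assay on BHK cells (Mesocricetus auratus) for cytotoxicity, read by MTT assay (on this read-out higher numbers stand for lower toxicity in this test and lower numbers for higher toxicity in this test), compound 1 gives > 500000 nM, a limit of the assay.
compound 2 `CC(C)(C)C(=O)N(CCCCCCN1C[C@H](O)[C@@H](O)[C@H](O)[C@H]1CO)c1cc(F)ccc1F`: in this assay compound 2 gives > 500000 nM, again a limit.
compound 3 `CC(C)(C)C(=O)N(CCCCCCN1C[C@H](O)[C@@H](O)[C@H](O)[C@H]1CO)C1CC1`: in this assay compound 3 gives > 500000 nM, also a limit.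

Compound 3 therefore stands at the limit of the assay, where all three values shown sit (the limit of > 500000 nM in this assay, at which 3 of the 3 values shown sit). None of the three amide substituents gives a readable number. The steps between them, a step that the two limits leave unreadable from compound 1 to compound 2, a step that the two limits leave unreadable from compound 1 to compound 3 and a step that the two limits leave unreadable from compound 2 to compound 3, cannot be sized. Each pair is bounded by the same limit.

The next compound, compound 4 `CC(C)(C)C(=O)N(CCCCCCN1C[C@H](O)[C@@H](O)[C@H](O)[C@H]1CO)C1CCC1`, differs from compound 3 in one place: cyclobutyl in place of cyclopropyl on an amide-type nitrogen. The cyclobutyl group of compound 4 lies between the cyclopropyl of compound 3 and the cyclohexyl of compound 1 in ring size, and neither of those produced a readable value. Within the data shown here, no measured step bears on this change with a readable size; the only guide is that every amide substituent tried so far sits at the limit.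

For compound 4 the expectation is accordingly no readable toxicity, with an estimated step of a number no higher from compound 3 to compound 4 (the limit leaves the size open) from compound 3 and an estimate of 500000 nM (range 250000 nM to 1000000 nM), most likely reported again as a limit.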

Compound 4, half-maximal cytotoxic concentration: > 500000 nM
Compound 4 gave a limit, no number (the forecaster's own chance of this, stated with the estimate: 85%); the middle value sits exactly at the limit.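

In this assay compound 4 gives > 500000 nM, a limit of the assay and not a number. No step from compound 1, compound 2 or compound 3 to compound 4 can be read: the limit of > 500000 nM in this assay, at which 4 of the 4 values shown sit.

The compounds shown leave open whether these amide substituents differ at all in this read-out.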